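Methoxy in Place of Chloro on a Benzylamine Sulfonamide

A few compounds are considered here, and "the series" means these few. Any claim that something is new, unique, unknown or untested is made for them only; others in the source may bear on it.

Measured so far:
Compound 1, `O=S(=O)(NCCCNCc1ccccc1Cl)c1cc(C(F)(F)F)cc(C(F)(F)F)c1`, gives 11000 nM in a functional assay on BXPC-3 cells (Homo sapiens) for inhibition, read by MTT assay, with a stated time of 72 h; a lower number here means a stronger inhibitor of growth, a higher number a weaker inhibitor of growth.
Compound 2, `O=S(=O)(NCCCNCc1cccc(Cl)c1)c1cc(C(F)(F)F)cc(C(F)(F)F)c1`, gives 3800 nM in this assay.

Both compounds share the same core, a sulfonamide joined through a three-carbon chain to an amine that carries a chlorobenzyl group. Among the two numbers shown, compound 1 stands highest; its only neighbour is compound 2, and the step of a 2.9-fold lower number from compound 1 to compound 2 (0.46 log units; beyond the scatter) comes from moving the chloro to a different position on the ring.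

Compound 3, `COc1ccccc1CNCCCNS(=O)(=O)c1cc(C(F)(F)F)cc(C(F)(F)F)c1`, differs from compound 1 in one place: methoxy in place of chloro on an aromatic carbon. Going by the values given here, the single measured step changes where the chloro sits, not what sits there, so it does not speak to an exchange of chloro for methoxy at the same position. Nothing measured here shows how this assay responds to such a swap. Among the compounds with values here, with no guiding step, the reasonable expectation is a change that stays within the scatter, which is what no change at the digits printed from compound 1 to compound 3 (within the scatter) expresses. Compound 3 is therefore expected to give about 11000 nM in this assay, most likely between 4000 nM and 30000 nM.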

Compound 3, concentration for 50% growth inhibition: 1700 nM
For compound 3 the middle estimate is 6.5-fold (0.81 log units) above the measured one; the whole stated range lies above it.
By their numbers in this assay, from the lowest: compound 3; then compound 2; then compound 1.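

In this assay, putting methoxy where chloro stood, on an aromatic carbon ortho to a large group, gives a 6.5-fold lower number from compound 1 to compound 3 (0.81 log units; beyond the scatter), so this position responds to which group it carries, and not only to where a chloro sits on the ring. The earlier step could not show this, as it only moved the chloro; the 2-methoxyphenyl group also improves on the better placed 3-chlorophenyl group, with a 2.2-fold lower number from compound 2 to compound 3 (0.35 log units; beyond the scatter), which leaves compound 3 with the lowest number of the three. Nothing available here explains why the methoxy compound stops growth at a lower concentration.

The compounds shown leave open whether the gain belongs to methoxy itself, which a hydroxy, an ethoxy or a fluoro at the same ring carbon would help to settle. They also leave open whether methoxy would lower the number in the ring place where compound 2 carries its chloro, and whether the result would hold with a longer chain between the sulfonamide and the amine.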